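Ether substituent trimming in the acid series

A few compounds are considered here, and "the series" means these few. Any claim that something is new, unique, unknown or untested is made for them only; others in the source may bear on it.

Measured so far in a functional assay on CHO cells for antagonist activity at sphingosine 1-phosphate receptor 2 (Homo sapiens), read by calcium flux; on this read-out higher numbers stand for weaker inhibition and lower numbers for stronger inhibition:
compound 1, `CCn1nc(CC(=O)Nc2ccc(OC(F)(F)F)c(Cl)c2)c2ccccc2c1=O`, gives 199 nM
compound 2, `O=C(O)Cn1nc(Cn2cc3cc(OCC4CC4)c(Cl)cc3n2)c2ccccc2c1=O`, gives 11 nM
compound 3, `C[C@H](C(=O)O)n1nc(Cn2cc3cc(OCC4CC4)c(Cl)cc3n2)c2ccccc2c1=O`, gives 3.2 nM

Compound 2 stands second of the three numbers. Its nearest neighbour is compound 3, reached by a 3.4-fold lower number from compound 2 to compound 3 (0.54 log units; beyond the scatter), a change on the saturated chain carbon bound to an aromatic nitrogen and a carbonyl carbon. Among the compounds with values here, compound 1, of quite different build, gives a markedly higher number than compound 2; no single-point step connects the two.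

The step to compound 4, `CCOc1cc2cn(Cc3nn(CC(=O)O)c(=O)c4ccccc34)nc2cc1Cl`, alters a different part of compound 2: methyl in place of cyclopropyl on a saturated chain carbon bound to an oxygen on an aromatic ring. Within the data shown here, no measured step touches this ether substituent. Among the measured compounds shown here, the one step with a number, from compound 2 to compound 3, concerns the chain on the ring nitrogen and gives no direct guidance here. The change is a shortening of the ether substituent, and for a shortening of this kind the number in this assay is expected to move somewhat upward, not far. The expected step is a 2.7-fold higher number from compound 2 to compound 4 (0.44 log units; beyond the scatter). Compound 4 is therefore estimated at 30 nM, with a range from 10 nM to 90 nM.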

Compound 4, half-maximal inhibitory concentration: 149 nM
The estimate for compound 4 lay 5.0-fold (0.70 log units) below the measured number; the measured number lies above the stated range.
By their numbers in this assay, from the lowest: compound 3; then compound 2; then compounds 4 and 1 (each within the scatter of the next).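

In this assay, within the data shown here, the change from cyclopropylmethoxy to ethoxy gives a 14-fold higher number from compound 2 to compound 4 (1.13 log units; beyond the scatter) and is classed as large, whereas the only earlier single-point step, a 3.4-fold lower number from compound 2 to compound 3 (0.54 log units; beyond the scatter), on the chain at the ring nitrogen, is classed as modest. Among these compounds, this is the first reading at the ether substituent, and it shows that the position is sensitive in the acid series: methyl does not stand in for cyclopropyl on the saturated chain carbon bound to an oxygen on an aromatic ring without a clear rise in the number. Nothing available accounts for the size of this step, so the shift remains an observation on a single pair.

A single pair cannot separate loss of the three-membered ring from loss of chain length; an open-chain propoxy or butoxy group, or a larger cyclobutylmethoxy group, would address that question. On these data alone, it also remains open whether the methyl on the chain carbon bound to an aromatic nitrogen and a carbonyl carbon, which lowers the number in compound 3, would have a comparable effect with ethoxy in place of cyclopropylmethoxy.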